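From compound 2 to compound 4: a longer chain

A few compounds are considered here, and "the series" means these few. Any claim that something is new, unique, unknown or untested is made for them only; others in the source may bear on it.

In a functional assay on KB cells (Homo sapiens) for inhibition, with a stated time of 72 h (on this read-out lower numbers stand for stronger inhibition and higher numbers for weaker inhibition), compound 1 `C=CCCCC(=O)N[C@@H](c1ccccc1)[C@@H](O)C(=O)OC1C[C@@](O)([C@H](C)OC(=O)CCCC=C)C(C)(C)C([C@@H](O)C(=O)[C@@]2(C)C[C@]3(OC(C)=O)CO[C@@H]3C[C@@H]2O)=C1C` gives 10 nM and compound 2 `C=CCCCCC(=O)N[C@@H](c1ccccc1)[C@@H](O)C(=O)OC1C[C@@](O)([C@H](C)OC(=O)CCCC=C)C(C)(C)C([C@@H](O)C(=O)[C@@]2(C)C[C@]3(OC(C)=O)CO[C@@H]3C[C@@H]2O)=C1C` gives 650 nM and so holds the higher of these two numbers. For compound 3 `CC(=O)O[C@@]12CO[C@@H]1C[C@H](O)[C@@](C)(C(=O)[C@H](O)C1=C(C)C3C[C@@](O)([C@H](C)OC(=O)CCC/C=C\CCCC(=O)N[C@@H](c4ccccc4)[C@@H](O)C(=O)O3)C1(C)C)C2` the result > 100000 nM is a limit of the assay and not a number.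

Compound 4 `C=CCCCCC(=O)N[C@@H](c1ccccc1)[C@@H](O)C(=O)OC1C[C@@](O)([C@H](C)OC(=O)CCCCC=C)C(C)(C)C([C@@H](O)C(=O)[C@@]2(C)C[C@]3(OC(C)=O)CO[C@@H]3C[C@@H]2O)=C1C` departs from compound 2 in one place, with allyl in place of vinyl on a saturated chain carbon, three bonds along the chain from a carbonyl carbon. For the measured compounds named here, one measured step bears on this. Going by the values given here, the same kind of change, made on another chain, produced a 65-fold higher number from compound 1 to compound 2 (1.81 log units; beyond the scatter) and is the only guide to size and direction. Since that single step lies on a different chain, a rise in the same direction but of smaller size is expected, and a 4.6-fold higher number from compound 2 to compound 4 (0.66 log units; beyond the scatter) is the estimated step in this assay for this change. Compound 4 is therefore estimated at 3000 nM (expected range 500 nM to 30000 nM).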

Compound 4, half-maximal inhibitory concentration: 500 nM
Compound 4: middle estimate off by 6.0-fold (0.78 log units), on the high side; the measured number falls inside the stated range.
By their numbers in this assay, from the lowest: compound 1; then compounds 4 and 2 (each within the scatter of the next). At a limit, above all of these: compound 3.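

In this assay the replacement of vinyl by allyl on a saturated chain carbon, three bonds along the chain from a carbonyl carbon, now gives a 1.3-fold lower number from compound 2 to compound 4 (0.11 log units; within the scatter) and so stays within the scatter on this chain. The same change on the other chain gave a 65-fold higher number from compound 1 to compound 2 (1.81 log units; beyond the scatter) and lay beyond the scatter, so among these compounds the outcome of one added carbon depends on which chain carries it. No measurement shown here bears on the reason for this contrast between the two chains.

Going by these compounds, it remains open whether a longer chain at this position would also leave the number within the scatter of compound 4. On these data alone, it is equally open whether an amine or a carboxylic acid at the end of this chain would be tolerated.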